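The compounds below may be only part of what the source reports. "The series", "measured", "known", "first", "only" and "open" are said of these compounds alone.

Compound 1 `Cc1ccccc1NC(=O)Nc1cccc(CNc2ncnc3ccccc23)c1` carries a 2-methylphenyl urea on the shared core. In a functional assay on MGC-803 cells (Homo sapiens) for antiproliferative activity, read by MTT assay (on this read-out higher numbers stand for weaker inhibition and lower numbers for stronger inhibition), compound 1 reaches only the limit of the measurement, > 50000 nM; this is a limit and not a number, namely (the limit of > 50000 nM in this assay, at which 1 of the 2 values shown sits). Compound 2 `Cc1ccc(NC(=O)Nc2cccc(CNc3ncnc4ccccc34)c2)cc1` differs from it only in the aryl group on the urea, and in this assay compound 2 gives 31200 nM. Going by the values given here, the step of an at least 1.6-fold lower number from compound 1 to compound 2 (0.20 log units; that floor lies within the scatter) is the only measured step, and its floor lies within the scatter.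

Compound 3 `O=C(Nc1ccc([N+](=O)[O-])cc1)Nc1cccc(CNc2ncnc3ccccc23)c1` is not yet measured. It differs from compound 1 as follows: 4-nitrophenyl in place of 2-methylphenyl on an amide-type nitrogen. Among the compounds with values here, the change from compound 1 to compound 2 likewise replaced the 2-methylphenyl by a group carrying its substituent on the 4-methylphenyl pattern and brought a number just inside the measured range; no measured step covers a nitro group at all. The expected step is an at least 1.6-fold lower number from compound 1 to compound 3 (0.22 log units; that floor lies within the scatter), small and of the same order as the measured one, and a limit instead of a number remains possible. Compound 3 is estimated at 30000 nM, between 10000 nM and 50000 nM.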

Compound 3, half-maximal inhibitory concentration: 9420 nM
Beside the measured number, compound 3's estimate is 3.2-fold (0.50 log units) above it; measured number below the stated range.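

In this assay, going by these compounds alone, 4-nitrophenyl in place of 2-methylphenyl on an amide-type nitrogen gives an at least 5.3-fold lower number from compound 1 to compound 3 (0.72 log units; beyond the scatter), the first step that clears the scatter. Within the data shown here, the single change of nitro in place of methyl on an aromatic carbon gives a 3.3-fold lower number from compound 2 to compound 3 (0.52 log units; beyond the scatter), so the identity of the group on this aryl ring moves the number, which the floor of the step between compound 1 and compound 2 could not show. Compound 1 remains a limit and not a number, so the step that starts from it gives only a floor: the limit of > 50000 nM in this assay, at which 1 of the 3 values shown sits.

The compounds shown cover only methyl and nitro on this aryl ring, so they do not tell whether the lower number belongs to nitro alone or would also come with 4-aminophenyl or 4-carboxyphenyl on the same amide-type nitrogen. As far as these compounds go, what 2-nitrophenyl would give also stays open, so the contribution of the substituent's placement cannot be separated for nitro as it can be partly bounded for methyl.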